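From compound 2 to compound 4: one group exchanged

The source may report more compounds than this note shows. Statements on the series, on what has been measured and on what is new or still open speak of the compounds shown alone.

Values in an ADME assay on BHK-21 cells (Mesocricetus auratus) for cytotoxicity, read by MTT assay; a lower number here means that less compound is tolerated, a higher number that more compound is tolerated:
Compound 1 (`COc1ccc(-c2nc3cc(/C(C)=N/NC(N)=O)ccc3n2C2CCCCC2)cc1`): ("not determined" (no result reported))
Compound 2 (`C/C(=N\NC(N)=O)c1ccc2c(c1)nc(-c1ccoc1)n2C1CCCCC1`): ("not determined" (no result reported))
Compound 3 (`C/C(=N\NC(N)=O)c1ccc2c(c1)nc(-c1ccccn1)n2C1CCCCC1`): (> 100000 nM), a limit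

On these data alone, compound 2 has no number to stand on ("not determined" (no result reported)), so its place in this assay remains open. Compound 3 alone gave a reading, and that reading is a limit (the limit of > 100000 nM in this assay, at which 1 of the 3 values shown sits). Compound 4 (`C/C(=N\NC(N)=S)c1ccc2c(c1)nc(-c1ccoc1)n2C1CCCCC1`) differs from compound 2 at a single place, on an amine nitrogen (a group of 3 heavy atoms (1 carbon, 1 nitrogen, 1 sulfur; no ring) in place of a group of 3 heavy atoms (1 carbon, 1 nitrogen, 1 oxygen; no ring), on an amine nitrogen). Within the data shown here, no measured step sizes this change. A moderate downward step in this assay is expected, though without a number for compound 2 this remains a tentative expectation. For compound 4 the estimated value is 60000 nM (expected range 20000 nM to 100000 nM).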

Compound 4, half-maximal cytotoxic concentration: > 100000 nM
Compound 4 was reported as a limit; the forecaster's own chance of this, stated with the estimate: 40%; at least 1.6-fold (0.22 log units) between middle value and limit.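

Compound 4 gives > 100000 nM, a limit, and compound 2 has no single number, so no step can be read between compound 2 and compound 4. The compounds shown leave open what exchanging the carbamoyl group does in this assay.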